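Swapping isopropyl for fluoro on a weak benzamide

The source may hold more compounds than are shown below. What is called first, only, known or untested is meant among the compounds shown, and "the series" means these compounds.

Compound 1 `Nc1ccccc1NC(=O)c1ccc(COc2ccc(Cl)cc2)cc1` gives > 32000 nM as a limit
Compound 2 `COc1ccc(OCc2ccc(C(=O)Nc3ccccc3N)cc2)cc1` gives 3480 nM as a number
Compound 3 `CC(C)c1ccc(OCc2ccc(C(=O)Nc3ccccc3N)cc2)cc1` gives > 32000 nM as a limit
Compound 4 `Nc1ccccc1NC(=O)c1ccc(COc2ccc(F)cc2)cc1` has not yet been measured

In a functional assay on MGC-803 cells (Homo sapiens) for antiproliferative activity, read by CCK-8 assay, with a stated time of 72 h (a higher number here means a weaker inhibitor, a lower number a stronger inhibitor), compound 3 stands only at a limit, reported as > 32000 nM and not as a number. Going by the values given here, the series offers a single numerical reading: compound 2 gives 3480 nM and is the only compound to escape the limit of > 32000 nM in this assay, at which 2 of the 3 values shown sit, so far.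

Among the compounds with values here, the step to compound 4 puts fluoro in place of isopropyl on an aromatic carbon, para to a large group fluoro in place of isopropyl on an aromatic carbon and fluoro itself appears in no measured compound. Within the data shown here, three measured steps bear on that same place. Methoxy in place of chloro gave an at least 9.1-fold lower number from compound 1 to compound 2 (0.96 log units; beyond the scatter) and isopropyl in place of methoxy gave an at least 9.1-fold higher number from compound 2 to compound 3 (0.96 log units; beyond the scatter) while isopropyl in place of chloro gave a step that the two limits leave unreadable from compound 1 to compound 3 in the data.

A lower number is therefore expected in this assay but only cautiously, since neither compound 1 nor compound 3 yields a number. The expected change is an at least 3.5-fold lower number from compound 3 to compound 4 (0.55 log units; beyond the scatter) and it may prove no more than modest. For compound 4 the estimate is 9000 nM with an expected range from 2500 nM to 32000 nM and a real chance of another limit.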

Compound 4, half-maximal inhibitory concentration: 4970 nM
Compound 4: the middle estimate sits 1.8-fold (0.26 log units) above what was measured; measured number inside the range.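

In this assay, compound 4 shows that methoxy is not alone in giving a number at this place, on an aromatic carbon para to a large group: fluoro in place of isopropyl gives an at least 6.4-fold lower number from compound 3 to compound 4 (0.80 log units; beyond the scatter), and fluoro in place of chloro gives an at least 6.4-fold lower number from compound 1 to compound 4 (0.80 log units; beyond the scatter), so exchanging one halogen for another here separates a limit from a number. Fluoro in place of methoxy gives a 1.4-fold higher number from compound 2 to compound 4 (0.15 log units; within the scatter), so the two groups that yield numbers cannot be told apart in this assay, although they share neither size nor atoms. The sizes of the two steps out of the limits remain open-ended, since the readings for compound 1 and compound 3 are limits and not numbers: the limit of > 32000 nM in this assay, at which 2 of the 4 values shown sit.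

The compounds shown leave open how far compound 1 and compound 3 really lie from compound 2 and compound 4, and so whether chloro and isopropyl differ from each other at all. They also leave open where a nitrile, an amine, a hydroxyl or a trifluoromethyl group at this same place would fall, whether with fluoro and methoxy or with chloro and isopropyl.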